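A few compounds are considered here, and "the series" means these few. Any claim that something is new, unique, unknown or untested is made for them only; others in the source may bear on it.

Going by the values given here, in a functional assay on A-375 cells (Homo sapiens) for antiproliferative activity, read by MTT assay, with a stated time of 48 h, in the presence of a further agent that is not named here (on this read-out lower numbers stand for stronger inhibition and higher numbers for weaker inhibition), two compounds have numbers so far. Compound 1 `O=C(Nc1ccc(-n2ccc3c(NC(=O)c4ccccc4)nccc32)cc1)Nc1ccc(Cl)c(C(F)(F)F)c1` gives 2400 nM. Among the compounds with values here, compound 2 `Nc1nccc2c1ccn2-c1ccc(NC(=O)Nc2cccc(C(F)(F)F)c2)cc1` gives 5400 nM, the higher of the two numbers; the gap from compound 1 to compound 2 lies beyond the usual scatter, but these two compounds differ in more than one place, so their values show only that compound 2 is the weaker of the pair. Compound 3 `Nc1nccc2c1ccn2-c1ccc(NC(=O)Nc2ccc(Cl)c(C(F)(F)F)c2)cc1` has not yet been measured in this assay. It differs from compound 2 in a single place: chloro in place of hydrogen on an aromatic carbon of a six-membered aromatic ring of carbon only, ortho to a trifluoromethyl group. The same chloro-bearing ring is present in compound 1, whose 2400 nM stands below that of compound 2, though its core carries a different group, so no clean one-change comparison exists. Compound 3 is therefore expected to show a modest step toward stronger inhibition, a 2.1-fold lower number from compound 2 to compound 3 (0.32 log units; beyond the scatter), of a size that may or may not clear the scatter. The value of compound 3 in this assay is estimated at 2600 nM, expected to fall between 1000 nM and 6500 nM.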

Compound 3, half-maximal inhibitory concentration: 8000 nM
The estimate for compound 3 lay 3.1-fold (0.49 log units) below the measured number; the measured number lies above the stated range.
By their numbers in this assay, from the lowest: compound 1; then compounds 2 and 3 (each within the scatter of the next).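

In this assay, chloro in place of hydrogen on an aromatic carbon, ortho to a trifluoromethyl group, gives a 1.5-fold higher number from compound 2 to compound 3 (0.17 log units; within the scatter) and so does not separate compound 2 from compound 3 at this position. Compound 3 also provides a one-place comparison with compound 1 on the same chloro-bearing ring: hydrogen in place of benzoyl on a nitrogen on an aromatic ring gives a 3.3-fold higher number from compound 1 to compound 3 (0.52 log units; beyond the scatter) and leaves compound 1 with the lower number, so the chloro group that both compounds carry does not account for that gap. Nothing given here offers a reason for either step.

The compounds shown leave open whether another group at this position, such as fluoro, methyl or methoxy, would give a step beyond the scatter. They also leave open whether the benzoyl step would recur on compound 2, which lacks the chloro group, and whether a smaller acyl group such as acetyl on that nitrogen would give a step of similar size.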